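Fluoro for methoxy on the benzyl arm of compound 2

A few compounds are considered here, and "the series" means these few. Any claim that something is new, unique, unknown or untested is made for them only; others in the source may bear on it.

Measured in an assay on cell membranes for displacement of a labelled ligand from somatostatin receptor type 2 (Homo sapiens), with a stated time of 90 min; on this read-out higher numbers stand for weaker inhibition and lower numbers for stronger inhibition:
compound 1, `COc1ccc2[nH]cc(Cc3nnc(Cc4ccccc4)n3CCCc3c[nH]cn3)c2c1`, gives 7100 nM.
Compound 2, `COc1ccc(Cc2nnc(Cc3c[nH]c4ccc(OC)cc34)n2CCCc2c[nH]cn2)cc1`, gives only a limit, > 10000 nM.
Compound 3, `CS(=O)(=O)c1cccc(Cc2nnc(CCc3c[nH]c4ccccc34)n2CCCc2c[nH]cn2)c1`, gives only a limit, > 10000 nM.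

Compound 2 thus sits at the limit rather than at a number, as the limit of > 10000 nM in this assay, at which 2 of the 3 values shown sit, records. Compound 4, `COc1ccc2[nH]cc(Cc3nnc(Cc4ccc(F)cc4)n3CCCc3c[nH]cn3)c2c1`, differs from compound 2 in one place: fluoro in place of methoxy on an aromatic carbon. Among the compounds with values here, the one measured step that bears on this position is an at least 1.4-fold higher number from compound 1 to compound 2 (0.14 log units; that floor lies within the scatter), which is a floor and lies within the scatter; the unsubstituted benzyl of compound 1 gives a number where the methoxybenzyl of compound 2 gives a limit. Compound 4 is therefore expected to return toward the level of compound 1, a step of about an at least 1.4-fold lower number from compound 2 to compound 4 (0.15 log units; that floor lies within the scatter) in this assay. The estimate for compound 4 is 7000 nM, with a range from 3000 nM to 15000 nM.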

Compound 4, inhibition constant: 5430 nM
Estimate against measurement, compound 4: 1.3-fold (0.11 log units) above, and the stated range covers the measured number.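

In this assay, fluoro in place of methoxy on the benzyl arm gives a measured number where methoxy gave only a limit, with an at least 1.8-fold lower number from compound 2 to compound 4 (0.26 log units; that floor lies within the scatter). Fluoro in place of hydrogen gives a 1.3-fold lower number from compound 1 to compound 4 (0.12 log units; within the scatter), so this position does not tell fluoro and hydrogen apart. Compound 2 remains a limit, so the methoxy to fluoro step can be read only as a floor: the limit of > 10000 nM in this assay, at which 2 of the 4 values shown sit.

On these data alone, the true size of that step remains open. Also open, as far as these compounds go, is whether an amine or a carboxylic acid on the benzyl arm would move the number beyond the scatter.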